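The source may hold more compounds than are shown below. What is called first, only, known or untested is meant among the compounds shown, and "the series" means these compounds.

Measured in a functional assay on IMR-32 cells (Homo sapiens) for cytotoxicity, read by sulforhodamine B assay, with a stated time of 48 h; a lower number here means a stronger inhibitor, a higher number a weaker inhibitor:
compound 1, `CC1=C(/C=C/C(=O)/C=C/c2ccc(Br)cc2)C(C)(C)CCC1`: 10400 nM
compound 2, `COc1ccccc1/C=C/C(=O)/C=C/C1=C(C)CCCC1(C)C`: 19200 nM

Compound 1 has the lower of the two numbers, and compound 2 comes nearest to it; the gap between the two lies within the usual scatter, so the two values cannot be told apart. Compound 3 `CC1=C(/C=C/C(=O)/C=C/c2ccoc2)C(C)(C)CCC1` has not yet been measured. It differs from compound 1 in one place: furan-3-yl in place of 4-bromophenyl on a double-bonded chain carbon bound to a double-bonded chain carbon. For the measured compounds named here, no step between measured compounds bears on this change, so the expectation rests on compound 1 alone, whose value in this assay is 10400 nM. For compound 3 the expected step is a 1.4-fold higher number from compound 1 to compound 3 (0.16 log units; within the scatter), a small shift toward a higher number that is not expected to go beyond the scatter. The estimate for compound 3 in this assay is 15000 nM, with a range from 5000 nM to 45000 nM.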

Compound 3, half-maximal inhibitory concentration: 56800 nM
Compound 3: the middle estimate sits 3.8-fold (0.58 log units) below what was measured, and the stated range ends below it.
By their numbers in this assay, from the lowest: compounds 1 and 2 (each within the scatter of the next); then compound 3.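

In this assay the change from 4-bromophenyl to furan-3-yl on a double-bonded chain carbon bound to a double-bonded chain carbon gives a 5.5-fold higher number from compound 1 to compound 3 (0.74 log units; beyond the scatter) and so shows that the number at this position depends on which aromatic ring it carries. Compounds 1 and 2, which both carry a six-membered aromatic ring of carbon only here, could not show this, and the step shows it for the five-membered ring with its oxygen. Nothing shown explains the size of this step.

The change alters ring size, the ring oxygen and the bromine together, and the compounds shown do not separate these. Still open, going by these compounds, is how a plain phenyl, a 4-chlorophenyl or a pyridin-3-yl ring would read at this position.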